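Swapping piperazine for hydroxypiperidine at the amide terminus

This account rests on a few compounds, and the source may have more. Where it says the series, first, only, none or still open, it means among the compounds named here.

Measured compounds:
- Compound 1, `O=C(CN1CN(c2ccccc2)C2(CCN(C(=O)c3ccc(C4CCCCC4)cc3)CC2)C1=O)NCCCCO`: 10300 nM
- Compound 2, `CC(C)(C)c1ccc(C(=O)N2CCC3(CC2)C(=O)N(CC(=O)N2CCNCC2)CN3c2ccccc2)cc1`: 22000 nM
- Compound 3, `COC(=O)CCCNC(=O)CN1CN(c2ccccc2)C2(CCN(C(=O)c3ccc(C4CCCCC4)cc3)CC2)C1=O`: 2500 nM

In an assay on HEK293 cells for displacement of a labelled ligand from NPC1-like intracellular cholesterol transporter 1 (Homo sapiens) (a higher number here means a weaker inhibitor, a lower number a stronger inhibitor), compound 2 gives the highest of the three numbers, that is, it is the weakest inhibitor shown. Compound 4, `CC(C)(C)c1ccc(C(=O)N2CCC3(CC2)C(=O)N(CC(=O)N2CCC(O)CC2)CN3c2ccccc2)cc1`, differs from compound 2 by one change: 4-hydroxypiperidin-1-yl in place of piperazin-1-yl on a carbonyl carbon. Going by the values given here, no measured step touches this part of the molecule. Among the compounds with values here, the only measured step, a 4.1-fold lower number from compound 1 to compound 3 (0.61 log units; beyond the scatter), concerns a different chain on a different compound and cannot be carried over. Without a bearing step, the expected change for compound 4 is none beyond the scatter, so a 1.4-fold lower number from compound 2 to compound 4 (0.14 log units; within the scatter) is the estimate. Compound 4 is therefore expected to give about 16000 nM, with a likely range from 5000 nM to 50000 nM.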

Compound 4, half-maximal inhibitory concentration: 4700 nM
Compound 4: middle estimate off by 3.4-fold (0.53 log units), on the high side; the measured number lies below the stated range.
By their numbers in this assay, from the lowest: compounds 3 and 4 (each within the scatter of the next); then compound 1; then compound 2.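

In this assay, putting 4-hydroxypiperidin-1-yl in place of piperazin-1-yl on the carbonyl carbon gives a 4.7-fold lower number from compound 2 to compound 4 (0.67 log units; beyond the scatter). Going by these compounds alone, this shows that the group at this position affects the number, something the earlier compounds could not show: their only step lay in a different chain on a different compound. Nothing shown explains the step. Still open, as far as these compounds go, is whether the difference follows the added hydroxyl or the lost ring nitrogen. Plain piperidine and morpholine at this position would help separate the two.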